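The compounds below may be only part of what the source reports. "The series", "measured", "known", "first", "only" and "open" are said of these compounds alone.

Compound 3 `N#C/C(C(=O)Nc1ccc(Cl)cc1)=c1/s/c(=C\c2ccc(Cl)cc2)c(=O)n1-c1ccccc1` stands, in a functional assay on HepG2 cells (Homo sapiens) for cytotoxicity, read by sulforhodamine B assay, with a stated time of 48 h (a lower number here means a stronger inhibitor, a higher number a weaker inhibitor), not at a number but at a limit of the measurement: compound 3 gives > 101000 nM, which is the limit of > 101000 nM in this assay, at which 1 of the 3 values shown sits. Within the data shown here, compound 2 `N#C/C(C(=O)Nc1ccc(Cl)cc1)=c1/s/c(=C\c2ccccc2)c(=O)n1-c1ccccc1` gives 49100 nM in this assay, and the move an at least 2.0-fold higher number from compound 2 to compound 3 (0.31 log units; beyond the scatter) is the only measured step that touches the part of the molecule changed here. Compound 1 `N#C/C(C(=O)Nc1ccccc1)=c1/s/c(=C\c2ccccc2O)c(=O)n1-c1ccccc1` carries the same 2-hydroxyphenyl group that enters below, on a core otherwise lacking the chloro on the anilide, and in this assay compound 1 gives 83100 nM. Compound 4 `N#C/C(C(=O)Nc1ccc(Cl)cc1)=c1/s/c(=C\c2ccccc2O)c(=O)n1-c1ccccc1` differs from compound 3 in one place: 2-hydroxyphenyl in place of 4-chlorophenyl on a double-bonded chain carbon bound to an aromatic carbon. Among the measured compounds shown here, no measured step runs from a 4-chlorophenyl to a 2-hydroxyphenyl on that carbon. For the measured compounds named here, the one step at this position, an at least 2.0-fold higher number from compound 2 to compound 3 (0.31 log units; beyond the scatter), shows that adding the chloro carried the number beyond the limit, so removing it points back toward the numbers of compound 2 and of compound 1, which both lie well inside the measurable range. The step of an at least 1.1-fold lower number from compound 3 to compound 4 (0.05 log units; that floor lies within the scatter) is therefore expected to be modest and toward a lower number, though a second limit cannot be ruled out. Compound 4 is estimated at 90000 nM, within 45000 nM to 200000 nM.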

Compound 4, half-maximal inhibitory concentration: 12400 nM
Beside the measured number, compound 4's estimate is 7.3-fold (0.86 log units) above it; measured number below the stated range.
By their numbers in this assay, from the lowest: compound 4; then compounds 2 and 1 (each within the scatter of the next). At a limit, above all of these: compound 3.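

With the 2-hydroxyphenyl group on the double-bonded chain carbon bound to an aromatic carbon, the number in this assay drops, with a 4.0-fold lower number from compound 2 to compound 4 (0.60 log units; beyond the scatter) and an at least 8.1-fold lower number from compound 3 to compound 4 (0.91 log units; beyond the scatter), the second step being read from a limit for compound 3 and so giving only a floor for its size. Hydroxy in place of hydrogen on that ring therefore moves the number the opposite way to the chloro seen there earlier, and with the hydroxy present, a chloro on the anilide also goes with a lower number, at a 6.7-fold lower number from compound 1 to compound 4 (0.83 log units; beyond the scatter). Chloro in place of hydrogen on an aromatic carbon thus has no single direction across these compounds, and its step does not carry over from one core to the other: the same change on two cores in this assay, an at least 2.0-fold higher number (0.31 log units; beyond the scatter) from compound 2 to compound 3 and a 6.7-fold lower number (0.83 log units; beyond the scatter) from compound 1 to compound 4, at least 13-fold (1.13 log units) apart, beyond the scatter of two such steps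

On these data alone, whether a methoxy or an amine in place of this hydroxy would keep the lower number remains open. As far as these compounds go, it is also open whether the step from adding the hydroxy would hold with a bromo or a methyl in place of the chloro on the anilide.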